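A few compounds are considered here, and "the series" means these few. Any claim that something is new, unique, unknown or untested is made for them only; others in the source may bear on it.

In a functional assay on MIA PaCa-2 cells (Homo sapiens) for inhibition, read by MTT assay, with a stated time of 4 days (on this read-out higher numbers stand for weaker inhibition and lower numbers for stronger inhibition), compound 1 `COc1cc(NC(C)CCCNC(=O)NNC(=O)NCCCCCO)c2ncccc2c1` gives 168000 nM. Compound 2 `COc1cc(NC(C)CCCNC(=O)NN)c2ncccc2c1` gives no number, only a limit of the assay, >= 250000 nM. Compound 3 `COc1cc(NC(C)CCCNC(=O)NNC(=O)NCCO)c2ncccc2c1` is also recorded only as a limit, >= 250000 nM. Most of this small set therefore sits at the limit of >= 250000 nM in this assay, at which 2 of the 3 values shown sit.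

Compound 4 `COc1cc(NC(C)CCCNC(=O)NNC(=O)N(CCO)CCO)c2ncccc2c1` differs from compound 3 by 2-hydroxyethyl in place of hydrogen on an amide-type nitrogen, with 2-hydroxyethyl in place of hydrogen on an amide-type nitrogen. Among the compounds with values here, two measured steps bear on this change. The first, with hydroxy in place of 3-hydroxypropyl on a saturated chain carbon, is an at least 1.4-fold higher number from compound 1 to compound 3 (0.17 log units; that floor lies within the scatter). The second, with (2-hydroxyethyl)carbamoyl in place of hydrogen on an amine nitrogen, is a step that the two limits leave unreadable from compound 2 to compound 3. Neither shows a change beyond the scatter, so no step beyond the scatter is expected in this assay, and another limit is the likeliest report. The expected step is a number no higher from compound 3 to compound 4 (the limit leaves the size open). For compound 4 the estimated value is 250000 nM, with an expected range of 120000 nM to 500000 nM.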

Compound 4, half-maximal inhibitory concentration: > 250000 nM
Compound 4: a limit, no number; the forecaster's own chance of this, stated with the estimate: 70%; the middle value sits exactly at the limit.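

In this assay, compound 4 carries a second 2-hydroxyethyl on the amide-type nitrogen of compound 3, and compound 4 is again recorded only as a limit, > 250000 nM. Within the data shown here, the steps to compound 4 from compound 2 and from compound 3 cannot be read, as both ends of each are limits, and the one readable step, with bis(2-hydroxyethyl)amino in place of (5-hydroxypentyl)amino on the carbonyl carbon, is an at least 1.4-fold higher number from compound 1 to compound 4 (0.17 log units; that floor lies within the scatter). Among the four compounds, only compound 1 now has a number, and the other three are limits: the limit of >= 250000 nM in this assay, at which 2 of the 4 values shown sit.

On these data alone, the size of any effect of the second 2-hydroxyethyl stays open. Also open, as far as these compounds go, is whether a 2-aminoethyl or a carboxymethyl group on this amide-type nitrogen would give a number rather than a limit.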